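Methoxy to phenoxy on two cores: cytotoxicity notes

The source may report more compounds than this note shows. Statements on the series, on what has been measured and on what is new or still open speak of the compounds shown alone.

Compound 1 `CCOC(=O)c1c(-c2cccc(OC)c2)[nH]c2cc(OC)c(OC)cc2c1=O` and compound 2 `CCOC(=O)c1c(-c2cccc(Oc3ccccc3)c2)[nH]c2cc(OC)c(OC)cc2c1=O` share one core; compound 3 `CCOC(=O)c1c(-c2cccc(OC)c2)[nH]c2cc(Cl)c(Cl)cc2c1=O` and compound 4 `CCOC(=O)c1c(-c2cccc(Oc3ccccc3)c2)[nH]c2cc(Cl)c(Cl)cc2c1=O` share another. The difference between the two cores is not broken down here. In an ADME assay on HepG2 cells (Homo sapiens) for cytotoxicity, read by luminescence, with a stated time of 72 h (a higher number here means that more compound is needed for the effect, a lower number that less compound is needed), compound 1 reaches only a limit, > 21500 nM. Compound 2 likewise gives only a limit in this assay, > 21500 nM. Compound 3 also stops at a limit in this assay, > 21500 nM. The change from compound 1 to compound 2, (phenyl in place of methyl on an oxygen on an aromatic ring), gives a step that the two limits leave unreadable from compound 1 to compound 2. The same change, (phenyl in place of methyl on an oxygen on an aromatic ring), carries compound 3 to compound 4. Since the limit of > 21500 nM in this assay, at which 3 of the 3 values shown sit, holds for every value shown, compound 4 is expected to sit at the limit as well, estimated at 30000 nM with a range from 15000 nM to 80000 nM. The step that the limit leaves unreadable from compound 3 to compound 4 is the expected outcome, most likely unreadable as a number.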

Compound 4, half-maximal effective concentration: > 21500 nM
Compound 4: a limit, no number; the forecaster's own chance of this, stated with the estimate: 85%; the middle value is on the limit's open side.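

Going by these compounds alone, compound 3 and compound 4 both give only a limit, so no step between them can be read as a number. The compounds shown leave open whether methoxy to phenoxy changes cytotoxicity at all on either core.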